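The source may hold more compounds than are shown below. What is called first, only, known or untested is meant among the compounds shown, and "the series" means these compounds.

Measured compounds:
- compound 1, `Cn1cc(-c2cnc(NCc3c(F)ccc4c3CCO4)c3cn[nH]c(=O)c23)cn1`: 21 mL.min-1.g-1
- compound 2, `Fc1ccc2c(c1CNc1ncc(Oc3ccccc3)c3nncn13)CCO2`: 18 mL.min-1.g-1
- compound 3, `CN(c1ccn(C)n1)c1cnc(NCc2c(F)ccc3c2CCO3)n2cnnc12`: 11 mL.min-1.g-1

In an ADME assay on microsomes from liver (Homo sapiens) for metabolic stability, read by LC-MS, using NADPH, with stated times of 5 min and 30 min, tested at 1 uM (a higher number here means faster removal of the compound, a lower number slower removal), compound 1 gives 21 mL.min-1.g-1, the highest of the three numbers, though compound 2 with 18 mL.min-1.g-1 and compound 3 with 11 mL.min-1.g-1 both sit within the scatter of it, so no real order among them can be claimed.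

Compound 4, `Cc1nn(C)cc1-c1cnc(NCc2c(F)ccc3c2CCO3)c2cn[nH]c(=O)c12`, is not yet measured. It differs from compound 1 in one place: methyl in place of hydrogen on an aromatic carbon.

Going by the values given here, the only measured step, a 1.6-fold lower number from compound 2 to compound 3 (0.21 log units; within the scatter), swaps one large group for another on a different core and so says nothing about adding a methyl to a pyrazole ring. Among the compounds with values here, with no step that bears on this change, the expectation is simply that a single methyl on a five-membered ring leaves the number close to that of compound 1, with no step beyond the scatter in either direction.

Compound 4 is therefore estimated at 20 mL.min-1.g-1 in this assay, within a range of 10 mL.min-1.g-1 to 40 mL.min-1.g-1, a step of a 1.1-fold lower number from compound 1 to compound 4 (0.02 log units; within the scatter) that is expected to stay within the scatter.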

Compound 4, intrinsic clearance in microsomes: 27 mL.min-1.g-1
Compound 4: the middle estimate sits 1.4-fold (0.13 log units) below what was measured; low and high end bracket the measured number.
By their numbers in this assay, from the lowest: compounds 3, 2, 1 and 4 (each within the scatter of the next, the first and the last beyond it).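

In this assay, turning a 1-methyl-1H-pyrazol-4-yl group into a 1,3-dimethyl-1H-pyrazol-4-yl group gives a 1.3-fold higher number from compound 1 to compound 4 (0.11 log units; within the scatter). Going by these compounds alone, this is the only direct reading of this position: a methyl on the aromatic carbon next to the ring atom that bears a large group does not move the rate of removal beyond the usual scatter of the assay. No measurement shown here speaks to what lies behind this small step.

Going by these compounds, whether an ethyl, a methoxy or an amine on this same carbon would move the number beyond the scatter stays open. Within the data shown here, equally open is whether the same methyl would read alike on a core other than the one shared by compound 1 and compound 4.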